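Swapping a hydroxy for a nitro on a weak inhibitor

The compounds below may be only part of what the source reports. "The series", "measured", "known", "first", "only" and "open" are said of these compounds alone.

compound 1 `COc1cc(O)cc(O)c1C(=O)/C=C/c1ccc(O)cc1`: 40200 nM
compound 2 `COc1cc(/C=C/C(=O)c2c(O)cc(O)cc2OC)ccc1O`: > 50000 nM

For the measured compounds named here, in a functional assay on HepG2 cells (Homo sapiens) for inhibition, read by MTT assay, with a stated time of 72 h (on this read-out higher numbers stand for weaker inhibition and lower numbers for stronger inhibition), compound 1 is the only compound with a measured number. Compound 2 gives only a limit of the assay, (the limit of > 50000 nM in this assay, at which 1 of the 2 values shown sits). Going by the values given here, the one measured step, an at least 1.2-fold higher number from compound 1 to compound 2 (0.09 log units; that floor lies within the scatter), arises from methoxy in place of hydrogen on an aromatic carbon and does not touch the place changed here. Compound 3 `COc1cc(O)cc(O)c1C(=O)/C=C/c1ccc([N+](=O)[O-])cc1` differs from compound 1 by nitro in place of hydroxy on an aromatic carbon. Among the compounds with values here, no measured step bears on nitro in place of hydroxy, so no change beyond the scatter is expected. Compound 3 is estimated at 45000 nM, between 15000 nM and 150000 nM. That estimate means an expected step of a 1.1-fold higher number from compound 1 to compound 3 (0.05 log units; within the scatter).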

Compound 3, half-maximal inhibitory concentration: 41000 nM
Beside the measured number, compound 3's estimate is 1.1-fold (0.04 log units) above it; measured number inside the range.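

In this assay, replacing the hydroxy with nitro at this position, para to a large group, gives a 1.0-fold higher number from compound 1 to compound 3 (0.01 log units; within the scatter). The hydrogen-bond donor of the hydroxy is therefore not needed for the weak inhibition seen with compound 1. Little room remains over these numbers, so any further weakening from a change at this position could hardly be seen: the limit of > 50000 nM in this assay, at which 1 of the 3 values shown sits.

As far as these compounds go, whether an amine or a carboxylic acid at this position would give stronger inhibition stays open.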